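The compounds below may be only part of what the source reports. "The series", "measured", "known", "first", "only" and "open" are said of these compounds alone.

Compound 3 `Nc1nc(N)c2c(-c3cc4ccccc4o3)cn([C@@H]3O[C@H](CO)[C@@H](O)[C@H]3O)c2n1` sits in a functional assay on K562 cells (Homo sapiens), read by MTT assay, with a stated time of 72 h (on this read-out lower numbers stand for stronger inhibition and higher numbers for weaker inhibition), at a limit of the assay, > 20000 nM, and not at a number. Compound 1 `Nc1nc(N)c2c(-c3ccsc3)cn([C@@H]3O[C@H](CO)[C@@H](O)[C@H]3O)c2n1` likewise reaches only a limit in this assay, > 20000 nM. Compound 2 `COc1nc(N)nc2c1c(-c1cc3ccccc3o1)cn2[C@@H]1O[C@H](CO)[C@@H](O)[C@H]1O` gives a number in this assay, 15500 nM. Two of the three values shown thus rest at the limit of > 20000 nM in this assay, at which 2 of the 3 values shown sit, and compound 3 stands among them, at the weak end of what the numbers can show. The step that the two limits leave unreadable from compound 1 to compound 3 cannot be read, while the step of an at least 1.2-fold higher number from compound 2 to compound 3 (0.11 log units; that floor lies within the scatter) gives only a floor.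

Compound 4 `Nc1nc(N)c2c(-c3ccoc3)cn([C@@H]3O[C@H](CO)[C@@H](O)[C@H]3O)c2n1` differs from compound 3 in one place: furan-3-yl in place of 1-benzofuran-2-yl on an aromatic carbon. Among the compounds with values here, no measured step covers this exact exchange. The nearest guide is compound 1, whose thiophen-3-yl group is, like furan-3-yl, a single five-membered aromatic ring with one hetero atom, and whose value is a limit; the step that the two limits leave unreadable from compound 1 to compound 3 from that compound to compound 3 shows no readable gain from the larger group. Compound 4 is therefore expected to remain at or beyond the limit, with a step that the limit leaves unreadable from compound 3 to compound 4 that is not expected to be read beyond the scatter. Compound 4 is estimated at 25000 nM, within 12000 nM to 60000 nM.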

Compound 4, half-maximal inhibitory concentration: > 20000 nM
Compound 4 ended at the assay's limit (the forecaster's own chance of this, stated with the estimate: 80%); the middle value is on the limit's open side.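

Within the data shown here, compound 1, compound 3 and compound 4 all stop at a limit in this assay, so no step among them can be read: the limit of > 20000 nM in this assay, at which 3 of the 4 values shown sit.

The compounds shown leave open how far each of the three lies past that limit, and whether furan-3-yl, thiophen-3-yl and 1-benzofuran-2-yl differ at all on this shared core.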